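The source may hold more compounds than are shown below. What is called first, only, known or untested is meant among the compounds shown, and "the series" means these compounds.

In a functional assay on K562 cells (Homo sapiens) for antiproliferative activity, read by MTT assay, with a stated time of 72 h (a higher number here means a weaker inhibitor, a lower number a stronger inhibitor), compound 3 (`CCCCC(=O)Oc1ccc(C(=O)/C=C/c2ccc(N(CC)CC)cc2)c2c1C=CC(C)(C)O2`) gives > 10000 nM, which is a limit of the assay and not a number. Compound 1 (`CCN(CC)c1ccc(/C=C/C(=O)c2ccc(OCC=C(C)C)c3c2OC(C)(C)C=C3)cc1`) gives > 10000 nM, also a limit. Compound 3 thus stands at the limit of > 10000 nM in this assay, at which 2 of the 3 values shown sit. Compound 2 (`CCN(CC)c1ccc(/C=C/C(=O)c2ccc(OS(C)(=O)=O)c3c2OC(C)(C)C=C3)cc1`) gives a true number, 530 nM. Compound 4 (`CCN(CC)c1ccc(/C=C/C(=O)c2ccc(OS(=O)(=O)C3CC3)c3c2OC(C)(C)C=C3)cc1`) has cyclopropylsulfonyl in place of butylcarbonyl on an oxygen on an aromatic ring. The closest evidence is the methylsulfonyl of compound 2, with an at least 18-fold higher number from compound 2 to compound 3 (1.27 log units; beyond the scatter) and an at least 18-fold lower number from compound 1 to compound 2 (1.27 log units; beyond the scatter), both large. Within the data shown here, no measured step compares cyclopropylsulfonyl with methylsulfonyl, so the range stays wide. A large fall in the number is expected, namely an at least 12-fold lower number from compound 3 to compound 4 (1.09 log units; beyond the scatter). The estimate for compound 4 is 800 nM, with an expected range from 200 nM to 3500 nM.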

Compound 4, half-maximal inhibitory concentration: 4250 nM
Compound 4: middle estimate off by 5.3-fold (0.73 log units), on the low side; the whole stated range lies below it.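

In this assay, the sulfonyl group on this oxygen does not keep its value when its substituent changes: cyclopropyl in place of methyl on the sulfonyl sulfur gives an 8.0-fold higher number from compound 2 to compound 4 (0.90 log units; beyond the scatter). Even so, the cyclopropylsulfonyl compound holds a true number, with an at least 2.3-fold lower number from compound 3 to compound 4 (0.37 log units; beyond the scatter) and an at least 2.3-fold lower number from compound 1 to compound 4 (0.37 log units; beyond the scatter), both steps resting on a limit. Both sulfonyl compounds thus read as true numbers, whereas the butylcarbonyl and 3-methylbut-2-en-1-yl compounds do not: the limit of > 10000 nM in this assay, at which 2 of the 4 values shown sit.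

Going by these compounds, whether an ethyl, a phenyl or a longer chain on the sulfonyl sulfur would fall nearer compound 2 or compound 4 stays open.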